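Trifluoromethyl in Place of Nitrile: Compound 3 Assessed

The compounds below may be only part of what the source reports. "The series", "measured", "known", "first", "only" and "open" are said of these compounds alone.

Measured compounds:
compound 1, `Cc1nc(-c2c(F)cccc2-c2ccc([C@@H](C)Nc3nccc(Cl)c3NC(=O)CC#N)cc2)no1`, 0.7 nM
compound 2, `C[C@@H](Nc1nccc(Cl)c1NC(=O)CC#N)c1ccc(-c2cccc(F)c2C#N)cc1`, 2 nM

In an assay on CHO cells for displacement of a labelled ligand from B1 bradykinin receptor (Homo sapiens) (on this read-out higher numbers stand for weaker inhibition and lower numbers for stronger inhibition), compound 1 gives 0.7 nM, and in this assay compound 2 gives 2 nM. Compound 2 therefore holds the higher of the two numbers, its nearest neighbour being compound 1 through the step of a 2.9-fold higher number from compound 1 to compound 2 (0.46 log units; beyond the scatter), which brought cyano in place of 5-methyl-1,2,4-oxadiazol-3-yl on an aromatic carbon.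

Compound 3, `C[C@@H](Nc1nccc(Cl)c1NC(=O)CC#N)c1ccc(-c2cccc(F)c2C(F)(F)F)cc1`, is not yet measured. It differs from compound 2 as follows: trifluoromethyl in place of cyano on an aromatic carbon. Within the data shown here, none of the measured steps tests this replacement; the only step available, a 2.9-fold higher number from compound 1 to compound 2 (0.46 log units; beyond the scatter), exchanges a different pair of groups, so it offers no direct guide beyond showing that changes at this part of the molecule have so far been modest. With nothing pointing strongly either way, compound 3 is expected to sit near compound 2, with a slight drift upward allowed for, giving an expected step of a 1.5-fold higher number from compound 2 to compound 3 (0.18 log units; within the scatter). Compound 3 is thus estimated at 3 nM, within a range from 1 nM to 10 nM.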

Compound 3, inhibition constant: 1.1 nM
Beside the measured number, compound 3's estimate is 2.7-fold (0.44 log units) above it, and the stated range covers the measured number.
By their numbers in this assay, from the lowest: compounds 1, 3 and 2 (each within the scatter of the next, the first and the last beyond it).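

In this assay the aromatic carbon ortho to a fluoro group now carries trifluoromethyl as well as cyano and 5-methyl-1,2,4-oxadiazol-3-yl, and the two new comparisons, a 1.8-fold lower number from compound 2 to compound 3 (0.26 log units; within the scatter) and a 1.6-fold higher number from compound 1 to compound 3 (0.20 log units; within the scatter), both lie within the scatter. Compound 3 therefore cannot be told apart from either neighbour, even though the earlier comparison, a 2.9-fold higher number from compound 1 to compound 2 (0.46 log units; beyond the scatter), lies beyond it, so the three groups form a graded series rather than two separate levels. Trifluoromethyl has no triple bond and no hydrogen-bond acceptor, where cyano has one of each, so neither feature is needed at this position for a number in this range, and no measurement at hand explains why these groups read so alike.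

The compounds shown leave open whether this position would accept a group of another kind, such as an amine, a carboxylic acid or a longer chain. They also leave open whether the same picture would hold if the neighbouring fluoro group gave way to hydrogen.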